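Compound 4 and the methyl that compound 3 lacks

This account rests on a few compounds, and the source may have more. Where it says the series, first, only, none or still open, it means among the compounds named here.

In a functional assay on the whole organism (arterial blood) with Rattus norvegicus as the target (on this read-out lower numbers stand for an effect already at smaller amounts and higher numbers for an effect only at larger amounts of compound), compound 3 `Cc1nc2cnccc2n1CC1CCN(C(=O)CCc2ccccc2)CC1` gives > 5 mg/kg, which is a limit and not a number. Compound 1 `Cc1nc2cnccc2n1CC1CCN(C(=O)CC(C)c2ccccc2)CC1` gives 0.033 mg/kg and compound 2 `Cc1nc2cnccc2n1CC1CCN(C(=O)CC(C)(C)c2ccccc2)CC1` gives 0.012 mg/kg. Two large steps separate these values from that limit: an at least 150-fold higher number from compound 1 to compound 3 (2.18 log units; beyond the scatter) and an at least 410-fold higher number from compound 2 to compound 3 (2.61 log units; beyond the scatter). Both steps remove methyl from a saturated chain carbon, while adding a methyl there gave a modest change, a 2.8-fold lower number from compound 1 to compound 2 (0.44 log units; beyond the scatter).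

Compound 4 `Cc1nc2cnccc2n1CC1CCN(C(=O)N[C@H](C)c2ccccc2)CC1` carries (1-phenylethyl)amino in place of phenethyl on a carbonyl carbon. The entering group holds a methyl on a saturated chain carbon, as compound 1 does. Among the measured compounds shown here, no measured step covers the nitrogen or the defined stereocentre, so the methyl steps are only a partial guide. A large move toward a lower number in this assay is therefore expected, and the estimated change is an at least 83-fold lower number from compound 3 to compound 4 (1.92 log units; beyond the scatter). Compound 4 is estimated at 0.06 mg/kg, with an expected range from 0.01 mg/kg to 1 mg/kg.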

Compound 4, dose for 50% inhibition: 0.017 mg/kg
Beside the measured number, compound 4's estimate is 3.5-fold (0.55 log units) above it; low and high end bracket the measured number.
By their numbers in this assay, from the lowest: compounds 2, 4 and 1 (each within the scatter of the next, the first and the last beyond it). At a limit, above all of these: compound 3.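

The step of an at least 290-fold lower number from compound 3 to compound 4 (2.46 log units; beyond the scatter) shows that this carbonyl carbon tolerates a substituent with a nitrogen, the amide hydrogen and a defined stereocentre, and that compound 4 keeps a value in the range of compound 1 and compound 2. The other step, a 1.9-fold lower number from compound 1 to compound 4 (0.29 log units; within the scatter), means that (1-phenylethyl)amino and 2-phenylpropyl on this carbonyl carbon cannot be told apart in this assay. Compound 3 stands at a limit and not at a number, so the first step gives only a bound: the limit of > 5 mg/kg in this assay, at which 1 of the 4 values shown sits.

The compounds shown leave open whether benzylamino, which lacks the methyl, would fall as far as compound 3 or hold the value of compound 4. They also leave open what the opposite stereocentre of (1-phenylethyl)amino, or a methyl in place of the amide hydrogen, would give.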